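From propyl to cyclohexyl on a shared core

The source may hold more compounds than are shown below. What is called first, only, known or untested is meant among the compounds shown, and "the series" means these compounds.

Among the measured compounds shown here, in a functional assay on DU-145 cells (Homo sapiens) for inhibition, read by trypan blue exclusion, with a stated time of 72 h (on this read-out higher numbers stand for weaker inhibition and lower numbers for stronger inhibition), compound 1 (`CCCn1c(=O)c(S(=O)(=O)c2ccc(F)cc2F)cc2cnc(Nc3ccc4[nH]ccc4c3)nc21`) gives 1000 nM and holds the lower of the two numbers so far. Compound 2 (`Cn1c(=O)c(S(=O)(=O)c2ccc(F)cc2F)cc2cnc(NCc3ccc4[nH]ccc4c3)nc21`) gives 100000 nM in the same test. Compound 3 (`O=c1c(S(=O)(=O)c2ccc(F)cc2F)cc2cnc(Nc3ccc4[nH]ccc4c3)nc2n1C1CCCCC1`) has not yet been measured and carries cyclohexyl in place of propyl on an aromatic nitrogen. For the measured compounds named here, no measured step covers this change. In this assay no step beyond the scatter is therefore expected, with the estimated 1.7-fold lower number from compound 1 to compound 3 (0.22 log units; within the scatter) leaning toward stronger inhibition. For compound 3 the expected value is 600 nM with an estimated range from 120 nM to 3000 nM on this read-out.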

Compound 3, half-maximal inhibitory concentration: 10000 nM
Compound 3: the middle estimate sits 17-fold (1.22 log units) below what was measured, outside the stated range (above it).
By their numbers in this assay, from the lowest: compound 1; then compound 3; then compound 2.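

In this assay, the group on this aromatic nitrogen matters: cyclohexyl in place of propyl gives a 10-fold higher number from compound 1 to compound 3 (1.00 log units; beyond the scatter), a step beyond the scatter toward weaker inhibition. Compound 1 and compound 2 differ in more than one place, and so could not single out this position. Nothing at hand accounts for the step. From the compounds shown here alone, with only propyl and cyclohexyl compared here, it remains open where isopropyl, cyclopropyl or a longer chain such as butyl would fall. Going by these compounds, whether the step would hold with other changes to the shared core also remains open.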